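The source may report more compounds than this note shows. Statements on the series, on what has been measured and on what is new or still open speak of the compounds shown alone.

Compound 1 `Nc1ccccc1NC(=O)c1ccc(NC(=S)NCc2cccc(F)c2)cc1` joins the shared core to a 3-fluorobenzyl thiourea. In an assay on isolated protein for inhibition of Nicotinamide phosphoribosyltransferase (Homo sapiens), read by fluorescence, with stated times of 5 min and 15 min (a lower number here means a stronger inhibitor, a higher number a weaker inhibitor), compound 1 gives only a limit, > 2000 nM. Compound 2 `Nc1ccc(CNC(=O)Nc2ccc(C(=O)Nc3ccccc3N)cc2)cn1` likewise stops at a limit in this assay, > 2000 nM. Compound 3 `Nc1ccccc1NC(=O)c1ccc(CNC(=O)c2cc3cnccc3[nH]2)cc1` also returns nothing but a limit in this assay, > 2000 nM. All three values sit at the limit of > 2000 nM in this assay, at which 3 of the 3 values shown sit, so compound 1 stands level with the other two and no order among them can be read from these numbers.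

Compound 4 `Nc1ccccc1NC(=O)c1ccc(NC(=S)NCc2ccc(Cl)nc2)cc1` has not yet been measured in this assay. It differs from compound 1 in one place: 6-chloropyridin-3-yl in place of 3-fluorophenyl on a saturated chain carbon bound to an amide-type nitrogen. Within the data shown here, no measured pair among the three compounds isolates a change of this kind, so the size of the step rests on expectation alone. Because every value shown sits at the limit of > 2000 nM in this assay, at which 3 of the 3 values shown sit, the data give no measured direction to lean on, and a wide range is the honest answer.

The estimate implies a step of an at least 1.6-fold lower number from compound 1 to compound 4 (0.22 log units; that floor lies within the scatter), toward stronger inhibition, expected rather than measured, and larger than the usual scatter at its middle but not assured. Compound 4 is estimated at 1200 nM, with a range from 100 nM to 10000 nM, and a real chance remains that this assay again reports only a limit.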

Compound 4, half-maximal inhibitory concentration: > 2000 nM
Compound 4 ended at the assay's limit; the forecaster's own chance of this, stated with the estimate: 50%; middle value at least 1.6-fold (0.22 log units) from the limit.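

In this assay compound 4 gives > 2000 nM, which is a limit of the assay. No step can be read between compound 1 and compound 4, because both stop at a limit: the limit of > 2000 nM in this assay, at which 4 of the 4 values shown sit.

The compounds shown leave open how strongly any of them inhibits in this assay, and whether 6-chloropyridin-3-yl in place of 3-fluorophenyl changes that at all.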